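A few compounds are considered here, and "the series" means these few. Any claim that something is new, unique, unknown or untested is made for them only; others in the source may bear on it.

Compound 1 `CN(C)C(=S)N/N=C/c1cc2cccnc2s1` gives > 100000 nM in a functional assay on HL-60 cells (Homo sapiens) for antiproliferative activity, read by sulforhodamine B assay, with a stated time of 72 h (a lower number here means a stronger inhibitor, a higher number a weaker inhibitor), which is a limit of the assay and not a number. Compound 2 `N#Cc1ccc(NC(=S)N/N=C/c2ccc3ccccc3n2)cc1` gives 4660 nM in this assay.

Among the measured compounds shown here, compound 2 stands as the only compound with a definite number in this assay; the other value recorded is a limit (the limit of > 100000 nM in this assay, at which 1 of the 2 values shown sits). Compound 3 `COc1cccc(NC(=S)N/N=C/c2ccc3ccccc3n2)c1` is not yet measured. It differs from compound 2 by 3-methoxyphenyl in place of 4-cyanophenyl on an amide-type nitrogen. For the measured compounds named here, no step between measured compounds guides this change, so only a small shift is expected, likely within or barely beyond the scatter, as a 1.5-fold higher number from compound 2 to compound 3 (0.18 log units; within the scatter). Compound 3 is estimated at 7000 nM, between 2000 nM and 25000 nM.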

Compound 3, half-maximal inhibitory concentration: 71200 nM
Beside the measured number, compound 3's estimate is 10-fold (1.01 log units) below it; the measured number lies above the stated range.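

The nitrogen bearing the aryl group proves sensitive in this assay: replacing 4-cyanophenyl with 3-methoxyphenyl, a group of the same heavy-atom count, gives a 15-fold higher number from compound 2 to compound 3 (1.18 log units; beyond the scatter). Among the compounds shown here, this is the first step that can be read, and it shows that the choice of aryl group at this place alone can change the value strongly. Nothing measured here accounts for the size of this step.

The substituent and its place on the ring change together, so the compounds shown cannot say which of the two carries the step. From the compounds shown here alone, how a plain phenyl group or an amine on the ring would read also remains open.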